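This account rests on a few compounds, and the source may have more. Where it says the series, first, only, none or still open, it means among the compounds named here.

In a functional assay on CCRF-CEM cells (Homo sapiens) (on this read-out higher numbers stand for weaker inhibition and lower numbers for stronger inhibition), compound 1 `Cc1ccc(/C=C/C(=O)Oc2ccc(/C=C3\CCCC(CN(C)C)C3=O)cc2)cc1` gives 7020 nM, the lower of the two numbers available, while compound 2 `O=C1CCCC/C1=C\c1ccc(OC(=O)c2ccc(Cl)cc2)cc1` gives 41000 nM, a gap beyond the scatter. Compound 3 `COc1ccc(C(=O)Oc2ccc(/C=C3\CCCC(CN(C)C)C3=O)cc2)cc1` has not yet been measured. It keeps the core of compound 1 and differs in one place: 4-methoxyphenyl in place of 2-(4-methylphenyl)ethenyl on a carbonyl carbon. Both groups hold one six-membered aromatic ring of carbon only. For the measured compounds named here, no measured pair shows what this exchange does, so the expectation in this assay is for no step beyond the scatter, anchored on compound 1 at 7020 nM. The estimated step is small, a 1.1-fold higher number from compound 1 to compound 3 (0.06 log units; within the scatter), and leans slightly towards weaker inhibition. For compound 3 the expected value is 8000 nM, with an estimated range from 3000 nM to 21000 nM.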

Compound 3, half-maximal inhibitory concentration: 5070 nM
Beside the measured number, compound 3's estimate is 1.6-fold (0.20 log units) above it; low and high end bracket the measured number.
By their numbers in this assay, from the lowest: compounds 3 and 1 (each within the scatter of the next); then compound 2.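

In this assay, putting 4-methoxyphenyl in place of 2-(4-methylphenyl)ethenyl on a carbonyl carbon gives a 1.4-fold lower number from compound 1 to compound 3 (0.14 log units; within the scatter). This is the only pair shown that differs at this position, and it shows that the double bond outside the aromatic ring can go and a hydrogen-bond acceptor can enter without a change that stands clear of the scatter. No independent measurement bears on why the two groups read alike.

The compounds shown do not tell whether an aromatic ring is needed on this carbonyl carbon, as neither a simple alkyl chain, an amine nor a carboxylic acid stands there. Compound 2 differs from compound 1 and compound 3 in more than one place, so it gives no reading of this exchange on another core.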